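A few compounds are considered here, and "the series" means these few. Any claim that something is new, unique, unknown or untested is made for them only; others in the source may bear on it.

Measured compounds:
Compound 1 `CC(C)CC1OCCC(Cl)=C1[Si](C)(C)C` gives 92000 nM in a functional assay on A2780 cells (Homo sapiens) for antiproliferative activity; on this read-out higher numbers stand for lower toxicity in this test and lower numbers for higher toxicity in this test.
Compound 2 `C[C@H]1CC(Cl)=C([Si](C)(C)C)[C@@H](C2CCCCC2)O1` gives 61000 nM.
Compound 3 `CC[C@H]1CC(Cl)=C([Si](C)(C)C)[C@@H](C2CCCCC2)O1` gives 75000 nM.

All three numbers in this assay lie within the usual scatter of one another, so compound 3 cannot be set apart from compound 1 or from compound 2 on this read-out. Among the measured compounds shown here, the single step between two measured compounds that differ in one place is a 1.2-fold higher number from compound 2 to compound 3 (0.09 log units; within the scatter), and it stays within the scatter.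

Compound 4 `C[Si](C)(C)C1=C(Cl)C[C@H](C2CCCCC2)O[C@@H]1C1CCCCC1` differs from compound 3 by cyclohexyl in place of ethyl on a saturated ring carbon. For the measured compounds named here, no measured step bears on this exchange directly: the one available step concerns a methyl in place of hydrogen on a chain carbon and was within the scatter, whereas the group entering here is a ring. Compound 1, which carries no cyclohexyl group, gives a value in the same scatter as compound 2 and compound 3, so the cyclohexyl groups present do not show a marked effect in this assay. Compound 4 is therefore expected to show a step of a 1.2-fold lower number from compound 3 to compound 4 (0.06 log units; within the scatter), that is, nothing beyond the scatter, with wide uncertainty. The estimate for compound 4 in this assay is 65000 nM, with a range from 25000 nM to 160000 nM.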

Compound 4, concentration lethal to 50% of the cells: 90000 nM
Compound 4: the middle estimate sits 1.4-fold (0.14 log units) below what was measured, and the stated range covers the measured number.
By their numbers in this assay, from the lowest: compounds 2, 3, 4 and 1 (each within the scatter of the next).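

On the saturated ring carbon next to the ring oxygen, this assay shows for cyclohexyl in place of ethyl a 1.2-fold higher number from compound 3 to compound 4 (0.08 log units; within the scatter) and for cyclohexyl in place of methyl a 1.5-fold higher number from compound 2 to compound 4 (0.17 log units; within the scatter). This place had so far carried only methyl and ethyl, and a non-aromatic ring of 6 heavy atoms now also leaves the number within the scatter, so no difference can be read among these three groups here. Nothing at hand accounts for this lack of a difference.

Going by these compounds, whether an amine or a carboxylic acid on this ring carbon would move the number beyond the scatter stays open. On these data alone, all four compounds carry the chloro group, so what a hydroxyl group in its place would do is equally open.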